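The source may report more compounds than this note shows. Statements on the series, on what has been measured and on what is new or still open speak of the compounds shown alone.

In a functional assay on PC-3 cells (Homo sapiens) for cytotoxicity, read by WST assay, with a stated time of 48 h (a higher number here means a weaker inhibitor, a lower number a stronger inhibitor), compound 3 (`COc1ccc2c(/C=C(\C#N)C(=O)c3c[nH]c4ccccc34)c[nH]c2c1`) gives 12500 nM and holds the lower of the two numbers, with compound 1 (`COc1ccc2[nH]cc(/C=C(\C#N)C(=O)c3c[nH]c4ccccc34)c2c1`) higher at 30500 nM and the gap beyond the scatter. For compound 2 (`N#C/C(=C\c1c[nH]c2cc(F)ccc12)C(=O)c1c[nH]c2ccccc12`) the reading > 50000 nM is a limit of the assay, not a number.

Compound 4 (`N#C/C(=C\c1c[nH]c2ccccc12)C(=O)c1c[nH]c2ccccc12`) has hydrogen in place of methoxy on an aromatic carbon of compound 3 (hydrogen in place of methoxy on an aromatic carbon). Among the compounds with values here, one measured step bears on this carbon, methoxy in place of fluoro (an at least 4.0-fold lower number from compound 2 to compound 3 (0.60 log units; beyond the scatter)), and it runs toward the lower number and lies beyond the scatter. Since compound 2 gives only a limit, that step sets a minimum size and does not fix the size. Compound 1 also carries a methoxy and stands at 30500 nM in this assay, so a methoxy does not by itself bring the number down to that of compound 3.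

Losing the methoxy is therefore expected to raise the number, by a step estimated as a 2.2-fold higher number from compound 3 to compound 4 (0.35 log units; beyond the scatter) and smaller than the measured one. For compound 4 the estimated value is 28000 nM (expected range 11000 nM to 65000 nM).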

Compound 4, half-maximal inhibitory concentration: > 50000 nM
Compound 4: no number, only a limit; the forecaster's own chance of this, stated with the estimate: 30%; middle value at least 1.7-fold (0.25 log units) away from the limit.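

In this assay, the methoxy on this carbon now stands out against plain hydrogen as well as against fluoro, with an at least 4.0-fold higher number from compound 3 to compound 4 (0.60 log units; beyond the scatter). Compound 4 gives a limit of the assay and not a number, so that step is only a floor, and the step between compound 2 and compound 4 cannot be read: the limit of > 50000 nM in this assay, at which 2 of the 4 values shown sit. The other methoxy compound adds less, with an at least 1.6-fold higher number from compound 1 to compound 4 (0.21 log units; that floor lies within the scatter), so this pair does not show that the methoxy of compound 1 lowers the number.

On these data alone, the true sizes of these steps stay open, as does the order of fluoro and hydrogen on this carbon. Also open, as far as these compounds go, is whether a hydroxyl, an ethoxy or an amine on this carbon would give a lower number than compound 3 at 12500 nM.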